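A few compounds are considered here, and "the series" means these few. Any claim that something is new, unique, unknown or untested is made for them only; others in the source may bear on it.

Two members of the series carry numbers in an assay on H4 cells for inhibition of Fatty-acid amide hydrolase 1 (Homo sapiens); on this read-out higher numbers stand for weaker inhibition and lower numbers for stronger inhibition. Compound 1 `CCCCCCCOc1ccc(NC(=O)Oc2ccccc2F)cc1` gives 28 nM in this assay, and compound 2 `CCCCCCCCCCCCOc1ccc(NC(=O)Oc2ccccc2F)cc1` gives 13 nM in this assay. Going by the values given here, the single step between them, a 2.2-fold lower number from compound 1 to compound 2 (0.33 log units; beyond the scatter), concerns the chain alone: pentyl in place of hydrogen on a saturated chain carbon, seven bonds along the chain from an oxygen on an aromatic ring. Among the two numbers so far compound 2 stands lowest, with compound 1 nearest at a higher number beyond the scatter.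

Compound 3 `CCCCCCCCCCCCOc1ccc(NC(=O)O/N=C/c2ccccc2)cc1` keeps the chain of compound 2 and changes the other end of the molecule: a group of 8 heavy atoms (7 carbon, 1 nitrogen; one six-membered aromatic ring of carbon only) in place of a group of 7 heavy atoms (6 carbon, 1 fluorine; one six-membered aromatic ring of carbon only), on an oxygen next to a carbonyl group. Among the compounds with values here, no measured step touches this position; the step from compound 1 to compound 2 bears on the chain only and gives no guidance on the group on the oxygen next to the carbonyl group. The change is therefore unanchored, and a wide range is the only defensible expectation. Compound 3 is expected to give 30 nM in this assay, with a range from 5 nM to 200 nM. The expected step of a 2.3-fold higher number from compound 2 to compound 3 (0.36 log units; beyond the scatter) may fall on either side of the scatter.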

Compound 3, half-maximal inhibitory concentration: 2.4 nM
Compound 3: the middle estimate sits 13-fold (1.10 log units) above what was measured; measured number outside the range, below it.
By their numbers in this assay, from the lowest: compound 3; then compound 2; then compound 1.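

In this assay, the group on an oxygen next to a carbonyl group proves open to change: 2-fluorophenyl gives way to a group of 8 heavy atoms with one nitrogen, one double bond outside aromatic rings and one hydrogen-bond acceptor, and the outcome is a 5.4-fold lower number from compound 2 to compound 3 (0.73 log units; beyond the scatter). Going by these compounds alone, this is the only measured step at this position, and it shows that, with the chain of compound 2 in place, 2-fluorophenyl is not required for a low number, since the entering group gives the lowest number of the three compounds. No measured evidence bears on this result, so the feature of the entering group that goes with the step remains unidentified.

With a single replacement shown, the contributions of the nitrogen, the double bond and the ring of the entering group cannot be separated, and a benzyl group on the same oxygen would be one direct comparison. The compounds shown also leave open whether the step would keep its direction and size with the shorter chain of compound 1.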